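This account rests on a few compounds, and the source may have more. Where it says the series, first, only, none or still open, it means among the compounds named here.

Compound 1 `COc1cc(C(=O)c2cn(-c3ccc(C)cc3)cc2-c2ccco2)cc(OC)c1OC` is the starting point of this series. In a functional assay on MCF7 cells (Homo sapiens) for inhibition, with a stated time of 96 h (a lower number here means a stronger inhibitor, a higher number a weaker inhibitor), compound 1 gives 22 nM. Compound 2 `COc1cc(C(=O)c2cn(-c3ccc(C)cc3)cc2-c2ccoc2)cc(OC)c1OC` differs from it by furan-3-yl in place of furan-2-yl on an aromatic carbon, and in this assay compound 2 gives 18 nM, a step of a 1.2-fold lower number from compound 1 to compound 2 (0.09 log units; within the scatter). Compound 3 `COc1cc(C(=O)c2cn(-c3ccc(F)cc3)cc2-c2ccco2)cc(OC)c1OC` carries a different core, the difference being (fluoro in place of methyl on an aromatic carbon); in this assay compound 3 gives 17 nM, a step of a 1.3-fold lower number from compound 1 to compound 3 (0.11 log units; within the scatter). Compound 4 `COc1cc(C(=O)c2cn(-c3ccc(F)cc3)cc2-c2ccoc2)cc(OC)c1OC` is not yet measured; it differs from compound 3 by furan-3-yl in place of furan-2-yl on an aromatic carbon. This is the same kind of change as that from compound 1 to compound 2, though the place is not identical: there the ring atom two bonds away bears a 4-methylphenyl group, here a 4-fluorophenyl group. The expected step for compound 4 is a 1.2-fold lower number from compound 3 to compound 4 (0.08 log units; within the scatter), beside the earlier 1.2-fold lower number from compound 1 to compound 2 (0.09 log units; within the scatter), and rests on that single measured pair. Compound 4 is therefore estimated at 14 nM, between 7 nM and 30 nM.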

Compound 4, half-maximal inhibitory concentration: 15 nM
The estimate for compound 4 lay 1.1-fold (0.03 log units) below the measured number, within the range that was stated.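

In this assay, furan-3-yl in place of furan-2-yl gives a 1.1-fold lower number from compound 3 to compound 4 (0.05 log units; within the scatter), and this agrees with the earlier step for the same change: the same change on two cores in this assay, a 1.2-fold lower number (0.09 log units; within the scatter) from compound 1 to compound 2 and a 1.1-fold lower number (0.05 log units; within the scatter) from compound 3 to compound 4, 1.1-fold (0.03 log units) apart, within the scatter of two such steps
Fluoro in place of methyl gives a 1.2-fold lower number from compound 2 to compound 4 (0.08 log units; within the scatter), which also agrees with its earlier counterpart: the same change on two cores in this assay, a 1.3-fold lower number (0.11 log units; within the scatter) from compound 1 to compound 3 and a 1.2-fold lower number (0.08 log units; within the scatter) from compound 2 to compound 4, 1.1-fold (0.03 log units) apart, within the scatter of two such steps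
Each change therefore behaves alike on the two cores shown, but as every step lies within the scatter, this shows only that neither change moves the number measurably here, not that either would carry over with a real effect or to other cores.

The compounds shown leave open how the number would respond to an amine or a carboxylic acid in place of the furan ring. They also leave open the effect of a longer chain in place of fluoro or methyl.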